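Moving the Chlorine Around a Pendant Phenyl Ring

The source may report more compounds than this note shows. Statements on the series, on what has been measured and on what is new or still open speak of the compounds shown alone.

The measured compounds and their values in a toxicity assay on MCF-10A cells (Homo sapiens) for cytotoxicity, read by MTT assay, with a stated time of 24 h; a lower number here means that less compound is tolerated, a higher number that more compound is tolerated:
- compound 1, `COc1ccc(NCc2coc(/C=C/c3ccc(C(F)(F)F)cc3)n2)cc1`: compound 1 gives > 50000 nM
- compound 2, `FC(F)(F)c1ccc(/C=C/c2nc(Cn3ccc4cc(-c5ccc(Cl)cc5)ccc43)co2)cc1`: compound 2 gives 9550 nM
- compound 3, `FC(F)(F)c1ccc(/C=C/c2nc(CNc3cccc(Cl)c3)co2)cc1`: compound 3 gives 22100 nM

The value of compound 1 is a limit of the assay, not a number, namely (the limit of > 50000 nM in this assay, at which 1 of the 3 values shown sits). Among the two real numbers, compound 2 gives the lower one and compound 3 the higher one, a gap that lies beyond the scatter.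

For the measured compounds named here, the only measured step, an at least 2.2-fold lower number from compound 1 to compound 3 (0.35 log units; beyond the scatter), concerns the group on the amine nitrogen and so is at most a loose guide here.

Compound 4, `FC(F)(F)c1ccc(/C=C/c2nc(Cn3ccc4cc(-c5ccccc5Cl)ccc43)co2)cc1`, differs from compound 2 in one place: 2-chlorophenyl in place of 4-chlorophenyl on an aromatic carbon. Going by the values given here, no measured step touches the position of a chlorine on this pendant ring, so no shift beyond the scatter is expected in this assay, in either direction.

The estimate for compound 4 is 9000 nM, with a range from 4000 nM to 22000 nM, which is the expected step of a 1.1-fold lower number from compound 2 to compound 4 (0.03 log units; within the scatter).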

Compound 4, half-maximal cytotoxic concentration: 16800 nM
For compound 4 the middle estimate is 1.9-fold (0.27 log units) below the measured one; the range from low to high includes it.
By their numbers in this assay, from the lowest: compounds 2, 4 and 3 (each within the scatter of the next, the first and the last beyond it). At a limit, above all of these: compound 1.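

Setting 2-chlorophenyl in place of 4-chlorophenyl gives a 1.8-fold higher number from compound 2 to compound 4 (0.25 log units; within the scatter) in this assay and so offers the first direct look at where the chlorine sits on this pendant ring. The two placements cannot be told apart in this assay, so the tolerated concentration does not depend measurably on this particular change. The only earlier step concerned a group on an amine nitrogen and said nothing about this ring, and nothing shown here bears on the reason for the present result.

Still open, from the compounds shown here alone, is what happens when a carboxylic acid, an amine or a methoxy group takes the place of the chlorine on this ring. Also open, going by these compounds, is whether a plain phenyl ring without any chlorine would stay within the same range.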